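The source may report more compounds than this note shows. Statements on the series, on what has been measured and on what is new or still open speak of the compounds shown alone.

In a functional assay on the whole organism for inhibition, with Mus musculus as the target (a lower number here means that less compound is needed, a higher number that more compound is needed for the effect), compound 1 (`CN1Cc2c(N)cccc2C(c2ccc(Cl)cc2)C1`) gives 1.6 mg/kg, compound 2 (`CCOC(=O)Nc1cccc2c1CN(C)CC2c1ccccc1`) gives 3.2 mg/kg and compound 3 (`CCCCOC(=O)Nc1cccc2c1CN(C)CC2c1ccccc1`) gives 4 mg/kg. Compound 3 thus stands level with compound 2, and its number lies beyond the scatter from that of compound 1. The move to compound 4 (`CC(C)NCC(=O)Nc1cccc2c1CN(C)CC2c1ccccc1`) is (isopropylamino)methyl in place of butoxy on a carbonyl carbon. Among the measured compounds shown here, only one measured step bears on this, and only loosely: a 1.3-fold higher number from compound 2 to compound 3 (0.10 log units; within the scatter). For the measured compounds named here, that step lengthens the chain and keeps the oxygen, and no measured step replaces the butoxy group with an amine-bearing one. No change beyond the scatter is therefore expected in this assay, with weak support. The expected step is a 1.3-fold higher number from compound 3 to compound 4 (0.10 log units; within the scatter). Compound 4 is estimated at 5 mg/kg, within an expected range of 1.5 mg/kg to 16 mg/kg.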

Compound 4, dose for half-maximal effect: 14 mg/kg
The estimate for compound 4 lay 2.8-fold (0.45 log units) below the measured number; low and high end bracket the measured number.
By their numbers in this assay, from the lowest: compounds 1, 2 and 3 (each within the scatter of the next, the first and the last beyond it); then compound 4.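

Among the compounds shown here, at the carbonyl carbon whose other neighbour is the amide-type nitrogen, (isopropylamino)methyl is the first change to move the number beyond the scatter in this assay (a 3.5-fold higher number from compound 3 to compound 4 (0.54 log units; beyond the scatter); a 4.4-fold higher number from compound 2 to compound 4 (0.64 log units; beyond the scatter)). Ethoxy and butoxy stay within the scatter of each other, so this exchange matters here where the chain extension did not. The exchange keeps the heavy-atom count and adds a hydrogen-bond donor, but nothing available explains the higher number.

As far as these compounds go, whether the amine nitrogen or the lost oxygen drives the step remains open. A plain pentyl chain or a dimethylamino group on the same carbon could separate the two.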